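The source may report more compounds than this note shows. Statements on the series, on what has been measured and on what is new or still open speak of the compounds shown alone.

The shared core is that of compound 1, `COC(=O)C1=C(C)NC(=O)NC1c1ccccc1`, and it is followed here through a small series of aryl variants. In an assay for inhibition of beta-glucuronidase (Bos taurus), read by spectrophotometry, with a stated time of 30 min (a lower number here means a stronger inhibitor, a higher number a weaker inhibitor), compound 1 gives "not active" (no number reported), so no single number marks where it stands; it is reported only as giving no measurable inhibition. Two relatives carry a number. Compound 2, `COC(=O)C1=C(C)NC(=O)NC1c1ccccc1OC`, gives 59200 nM in this assay, and compound 3, `COC(=O)C1=C(C)NC(=O)NC1c1ccc(C)o1`, gives 44200 nM. These two values lie within the usual scatter of each other, so no order between them is claimed.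

Compound 4, `COC(=O)C1=C(C)NC(=O)NC1c1ccc(Br)cc1`, is not yet measured. It differs from compound 1 by bromo in place of hydrogen on an aromatic carbon. Within the data shown here, no step between measured compounds corresponds to this change, so its size and direction cannot be read from the data. Given that compound 2 and compound 3 both fall in the weak range and compound 1 falls below detection, compound 4 is expected to land in a similarly weak region, with a real chance that only a limit is reported. The half-maximal inhibitory concentration of compound 4 is estimated at 50000 nM, within a range from 15000 nM to 200000 nM.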

Compound 4, half-maximal inhibitory concentration: 64100 nM
Compound 4: the middle estimate sits 1.3-fold (0.11 log units) below what was measured; the measured number falls inside the stated range.
By their numbers in this assay, from the lowest: compounds 3, 2 and 4 (each within the scatter of the next).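

In this assay, among these compounds, compound 4 gives 64100 nM and compound 1 gives "not active" (no number reported), so no step from compound 1 to compound 4 can be read. The compounds shown leave open what bromo in place of hydrogen does to inhibition. No further evidence bears on this result.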